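The source may hold more compounds than are shown below. What is called first, only, known or untested is meant among the compounds shown, and "the series" means these compounds.

In a functional assay on MCF7 cells (Homo sapiens) for antiproliferative activity, read by MTT assay, with a stated time of 48 h (a lower number here means a stronger inhibitor, a higher number a weaker inhibitor), three compounds that all carry a 4-bromophenyl group have been measured. Compound 1 `COc1ccc(/C=C/C(=O)Nc2cc(-c3ccc(Br)cc3)[nH]n2)cc1` gives 590 nM, compound 2 `O=C(/C=C/c1ccc(Br)cc1)Nc1cc(-c2ccc(Br)cc2)[nH]n1` gives 920 nM and compound 3 `O=C(/C=C/c1ccc(Cl)cc1)Nc1cc(-c2ccc(Br)cc2)[nH]n1` gives 770 nM. Compound 2 thus stands within the scatter of both others, as shown by a 1.6-fold higher number from compound 1 to compound 2 (0.19 log units; within the scatter) and a 1.2-fold lower number from compound 2 to compound 3 (0.08 log units; within the scatter).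

Compound 4 `Cc1ccc(-c2cc(NC(=O)/C=C/c3ccc(Br)cc3)n[nH]2)cc1` departs from compound 2 at the group the three measured compounds have in common, which changes from 4-bromophenyl to 4-methylphenyl: methyl in place of bromo on an aromatic carbon. This places methyl in place of bromo on an aromatic carbon, para to a large group.

Among the compounds with values here, no measured step touches that group, so the evidence is only indirect. The three measured steps are exchanges of a different kind of substituent on an aromatic carbon elsewhere in the molecule. Besides the two above, there is a 1.3-fold higher number from compound 1 to compound 3 (0.12 log units; within the scatter). All three stay within the scatter, and none replaces bromo with methyl. The series therefore offers no ground for a direction, and the expectation stays close to the value of compound 2, 920 nM.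

The expected change is a 1.1-fold lower number from compound 2 to compound 4 (0.03 log units; within the scatter), which means no step beyond the scatter. For compound 4 the estimate is 850 nM, with an expected range from 400 nM to 1800 nM.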

Compound 4, half-maximal inhibitory concentration: 1370 nM
The estimate for compound 4 lay 1.6-fold (0.21 log units) below the measured number; the measured number falls inside the stated range.
By their numbers in this assay, from the lowest: compounds 1, 3, 2 and 4 (each within the scatter of the next, the first and the last beyond it).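

In this assay, within the data shown here, the exchange of 4-bromophenyl for 4-methylphenyl gives the first measured step at this group, a 1.5-fold higher number from compound 2 to compound 4 (0.17 log units; within the scatter). With methyl in place of bromo, para to a large group, this single pair therefore does not separate the two substituents, and the change at this position stays within the scatter, as do the three exchanges measured elsewhere in the molecule. No measurement is at hand that would explain the size of this step or tie it to any property of bromo or methyl.

The compounds shown leave open whether the same exchange would give a similar step in the setting of compound 1 or of compound 3, as each is shown only with the 4-bromophenyl group. They also leave open how this position would respond to groups of a different kind, such as an amine, a carboxylic acid or a longer chain like propyl, in place of bromo or methyl.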